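Replacing a propyl amide with a 4-bromophenyl amide

A few compounds are considered here, and "the series" means these few. Any claim that something is new, unique, unknown or untested is made for them only; others in the source may bear on it.

Compound 1 `CN(C)c1ccc(C(=O)Nc2cccc(NC(=O)COc3ccc4c(c3)NC(=O)CC4)c2)cc1`: > 10000 nM (a limit)
Compound 2 `COc1ccc(OCC(=O)Nc2cccc(NC(=O)c3ccc(N(C)C)cc3)c2)cc1F`: 1820 nM
Compound 3 `CCCC(=O)Nc1cccc(NC(=O)COc2ccc3c(=O)ccoc3c2)c1`: 1430 nM

In an assay on isolated protein for inhibition of Rho-associated protein kinase 1 (Homo sapiens), read by scintillation counting, radiometric assay and 33P incorporation, with a stated time of 40 min, in the presence of a further agent that is not named here (a lower number here means a stronger inhibitor, a higher number a weaker inhibitor), compound 1 reaches only the assay limit of > 10000 nM. Compound 3 holds the lowest of the two numbers, and compound 2 sits within the scatter of it. Compound 4 `O=C(COc1ccc2c(=O)ccoc2c1)Nc1cccc(NC(=O)c2ccc(Br)cc2)c1` differs from compound 3 by 4-bromophenyl in place of propyl on a carbonyl carbon. For the measured compounds named here, the only measured step, an at least 5.4-fold lower number from compound 1 to compound 2 (0.73 log units; beyond the scatter), alters the group on the oxygen on a saturated carbon, a different place, so no measured step bears directly on this change. Compound 4 is therefore estimated to land near compound 3, with a step of a 1.6-fold lower number from compound 3 to compound 4 (0.20 log units; within the scatter) expected. Compound 4 is expected to give about 900 nM, between 200 nM and 4000 nM.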

Compound 4, half-maximal inhibitory concentration: 303 nM
Compound 4: the middle estimate sits 3.0-fold (0.47 log units) above what was measured; measured number inside the range.
By their numbers in this assay, from the lowest: compound 4; then compounds 3 and 2 (each within the scatter of the next). At a limit, above all of these: compound 1.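

The step at the carbonyl carbon shows that this position, on a carbonyl carbon whose other neighbour is an amide-type nitrogen, also affects the number in this assay; the earlier step changed only the group on the oxygen on a saturated carbon. Putting 4-bromophenyl in place of propyl here gives a 4.7-fold lower number from compound 3 to compound 4 (0.67 log units; beyond the scatter) and shows that an aromatic ring carrying bromine is tolerated at this position. No measurement shown bears on the cause of this step.

As far as these compounds go, it remains open whether the ring or the bromine accounts for the step. From the compounds shown here alone, how plain phenyl, 4-chlorophenyl, a longer alkyl chain or an amine would read at this position also remains open.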